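A few compounds are considered here, and "the series" means these few. Any claim that something is new, unique, unknown or untested is made for them only; others in the source may bear on it.

Measured so far:
compound 1 `CCCCNc1nc(N)nc(C)c1CCCCO` — 1310 nM
compound 2 `CCCCNc1nc(N)nc(C)c1CCCn1c(C)nc2ccccc21` — 366 nM

Both compounds were tested in an assay on HEK293 cells for agonist activity at Toll-like receptor 8 (Homo sapiens), read by spectrophotometry; on this read-out higher numbers stand for an effect only at larger amounts of compound and lower numbers for an effect already at smaller amounts. Compound 1 gives 1310 nM, the higher of the two numbers. Compound 2 gives 366 nM, and the gap between the two lies beyond the usual scatter of the assay, so compound 2 is the one that acts at the smaller amount. For the measured compounds named here, no single-point step between the two has been worked out, so only this comparison of the two values can be drawn.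

Compound 3 `CCCCNc1nc(N)nc(C)c1CCCC(C)(C)O` is not yet measured. It differs from compound 1 in one place: 1-hydroxy-1-methylethyl in place of hydroxymethyl on a saturated chain carbon, three bonds along the chain from an aromatic carbon. In words, the alcohol at the end of the chain is kept, but the carbon that carries it gains two methyl groups.

Going by the values given here, no measured pair shows such a change. The step in this assay is therefore expected to be modest and is estimated as a 1.5-fold lower number from compound 1 to compound 3 (0.16 log units; within the scatter). Compound 3 is therefore estimated at 900 nM, with a likely range from 300 nM to 3000 nM.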

Compound 3, half-maximal effective concentration: 1220 nM
Compound 3: middle estimate off by 1.4-fold (0.13 log units), on the low side; measured number inside the range.
By their numbers in this assay, from the lowest: compound 2; then compounds 3 and 1 (each within the scatter of the next).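

Putting 1-hydroxy-1-methylethyl in place of hydroxymethyl on a saturated chain carbon, three bonds along the chain from an aromatic carbon, gives in this assay a 1.1-fold lower number from compound 1 to compound 3 (0.03 log units; within the scatter), so this assay does not tell compound 1 and compound 3 apart. For the compounds shown here, this is the first single-place comparison, and it shows that two extra methyl groups can sit on the carbon carrying the alcohol without a shift that stands out from the scatter; the alcohol itself is kept, and the counts of hydrogen-bond donors and acceptors stay the same across the change. No independent measurement bears on why the number holds steady, so this pair records the outcome without explaining it.

One pair at one position cannot show how much of the chain end can vary, for instance whether an amine or a carboxylic acid in place of the alcohol would keep the number in the same region. It also leaves open whether a longer chain carrying the same alcohol, or a single added methyl group on the alcohol carbon, would behave as compound 3 does.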